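A few compounds are considered here, and "the series" means these few. Any claim that something is new, unique, unknown or untested is made for them only; others in the source may bear on it.

Measured so far in a functional assay on the whole organism (strain Wistar) for inhibition, with Rattus norvegicus as the target, read by paw edema, with stated times of 60 min and 24 h, at a dose of 100 mg/kg by the oral route; on this read-out higher numbers stand for more inhibition at the one dose given (going by the name of the read-out) and lower numbers for less inhibition:
compound 1 `COc1cc2c(cc1OC)C(CC(N)=O)CC2` gives 26.7%;
compound 2 `COc1cc2c(cc1OC)C(CC(=O)NC(C)C)CC2` gives 30%.

Compound 2 has only one companion on this read-out, compound 1, and the step of a number 3.3 percentage points higher from compound 1 to compound 2 (within the scatter) lies within the scatter, so the two stand together rather than apart. Compound 3 `CCCCNC(=O)CC1CCc2cc(OC)c(OC)cc21` is not yet measured; it differs from compound 2 by butyl in place of isopropyl on an amide-type nitrogen. Among the measured compounds shown here, the only measured step that touches the same place, the amide-type nitrogen, is a number 3.3 percentage points higher from compound 1 to compound 2 (within the scatter), and it did not move the number beyond the scatter. Exchanging one chain on that nitrogen for another therefore gives no ground to expect a shift of its own in this assay. The expected step of no change at the digits printed from compound 2 to compound 3 (within the scatter) is estimated to stay within the scatter. Compound 3 is thus estimated at 30%, with a range from 18% to 42%.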

Compound 3, a percentage reported as inhibition, in the whole organism at one dose (the size of the read-out at that dose, not a potency): 36.7%
Estimate against measurement, compound 3: 6.7 percentage points below; the range from low to high includes it.
By their numbers in this assay, from the lowest: compounds 1, 2 and 3 (each within the scatter of the next).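

In this assay, butyl in place of isopropyl on the amide-type nitrogen gives a number 6.7 percentage points higher from compound 2 to compound 3 (within the scatter) and so does not set the two chains apart. Even butyl in place of the amide hydrogen, the other step at this nitrogen, gives a number 10 percentage points higher from compound 1 to compound 3 (within the scatter) on this read-out, so hydrogen, isopropyl and butyl all stand together, and this position shows no clear preference among the three. No supporting measurement is available to explain these numbers.

From the compounds shown here alone, whether a longer chain such as octyl, or a benzyl group, on this nitrogen would bring a step beyond the scatter remains open. Going by these compounds, it also remains open whether a carboxylic acid or an amine in place of the amide would separate from these compounds in this assay.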